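Solubility notes: from compound 3 to compound 4

This account rests on a few compounds, and the source may have more. Where it says the series, first, only, none or still open, it means among the compounds named here.

Of the compounds shown here, three have been read in a physicochemical assay for solubility, read by chemiluminescence, measured as kinetic solubility (a lower number here means a less soluble compound, a higher number a more soluble compound), so far. Compound 1 (`CC(=O)NCc1cccc(Cn2nc(NS(=O)(=O)c3ccc(Cl)s3)c3c(C#N)cccc32)c1`) gives >= 155 ug/mL as a limit of the assay and not a number. Compound 2 (`CC(=O)NCc1cccc(Cn2nc(NS(=O)(=O)c3ccc(Cl)s3)c3c(C(C)O)cccc32)c1`) gives >= 208 ug/mL and this too is a limit. Going by the values given here, compound 3 (`COc1cccc2c1c(NS(=O)(=O)c1ccc(Cl)s1)nn2Cc1cccc(CNC(=O)C2CCO2)c1`) gives 124 ug/mL as the only true number in the set, so it is the only firm anchor available in this assay and cannot be ranked against the other two.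

Compound 4 (`COc1cccc2c1c(NS(=O)(=O)c1ccc(Cl)s1)nn2Cc1cccc(CNC(=O)C(C)(C)N)c1`) departs from compound 3 by one change on a carbonyl carbon whose other neighbours are an amide-type nitrogen, with 1-amino-1-methylethyl in place of oxetan-2-yl on a carbonyl carbon is the full count of that change.

Among the compounds with values here, the only measured step is a step that the two limits leave unreadable from compound 1 to compound 2 and its size cannot be read. Within the data shown here, it also lies at a different place, on an aromatic carbon, so no measured step bears on this change. The expectation therefore starts from compound 3 at 124 ug/mL and carries no direction. The estimated step is a 1.2-fold higher number from compound 3 to compound 4 (0.08 log units; within the scatter) and nothing beyond the scatter is expected. The estimate for compound 4 is 150 ug/mL with 70 ug/mL to 260 ug/mL as the expected range here.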

Compound 4, solubility: >= 180 ug/mL
Compound 4: no number, only a limit; the forecaster's own chance of this, stated with the estimate: 30%; at least 1.2-fold (0.07 log units) between middle value and limit.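

In this assay compound 4 gives >= 180 ug/mL, which is a limit of the assay and not a number. Going by these compounds alone, on a carbonyl carbon whose other neighbours are an amide-type nitrogen, 1-amino-1-methylethyl in place of oxetan-2-yl gives an at least 1.4-fold higher number from compound 3 to compound 4 (0.16 log units; that floor lies within the scatter), the first step with a readable size, although only its floor can be read and the step between compound 1 and compound 2 stays unreadable. The change removes a four-membered non-aromatic ring and brings in a hydrogen-bond donor, and the reading shows only that compound 4 reaches its limit with both of these differences in place: the limit of >= 180 ug/mL in this assay, at which 1 of the 4 values shown sits.

On these data alone, the true size of the step stays open, as does the question of whether the loss of the ring or the gain of the donor accounts for it, as the two arrive together in this one change. Also open, as far as these compounds go, is how a carboxylic acid, a simple amine or a longer chain ending in an amine would read on the same carbonyl carbon in this assay.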